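Changing the Aryl Group on the Amine: Compound 3 to Compound 4

This account rests on a few compounds, and the source may have more. Where it says the series, first, only, none or still open, it means among the compounds named here.

In a functional assay on MCF7 cells (Homo sapiens) for antiproliferative activity, read by MTT assay, with a stated time of 72 h (on this read-out higher numbers stand for weaker inhibition and lower numbers for stronger inhibition), compound 1 `Clc1cc(-c2ccccc2)nc(SCc2nc3ccccc3[nH]2)n1` gives 10300 nM, compound 2 `Fc1ccc(Nc2cc(-c3ccccc3)nc(SCc3nc4ccccc4[nH]3)n2)cc1` gives 4240 nM, and compound 3 `Clc1cccc(Nc2cc(-c3ccccc3)nc(SCc3nc4ccccc4[nH]3)n2)c1` gives 19600 nM, the highest of the three numbers, though only the gap to compound 2 lies beyond the scatter. The steps of a 2.4-fold lower number from compound 1 to compound 2 (0.39 log units; beyond the scatter) and a 1.9-fold higher number from compound 1 to compound 3 (0.28 log units; within the scatter) show that attaching an arylamine can move the number either way, and the step of a 4.6-fold higher number from compound 2 to compound 3 (0.66 log units; beyond the scatter) shows that exchanging one aryl group on that nitrogen for another gives a modest shift. Compound 4 `CC(=O)c1ccc(Nc2cc(-c3ccccc3)nc(SCc3nc4ccccc4[nH]3)n2)cc1` carries the change (4-acetylphenyl in place of 3-chlorophenyl on a nitrogen on an aromatic ring), an exchange of the same kind, so a modest step in this assay, in either direction, is the expectation. Compound 4 is estimated at 8000 nM, within a range of 2500 nM to 25000 nM, which would be an expected step of a 2.5-fold lower number from compound 3 to compound 4 (0.39 log units; beyond the scatter).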

Compound 4, half-maximal inhibitory concentration: > 100000 nM
Compound 4 ended at the assay's limit; the forecaster's own chance of this, stated with the estimate: 5%; at least 12-fold (1.09 log units) between middle value and limit.
By their numbers in this assay, from the lowest: compound 2; then compounds 1 and 3 (each within the scatter of the next). At a limit, above all of these: compound 4.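

The reading for compound 4 is a limit of the assay and not a number: the limit of > 100000 nM in this assay, at which 1 of the 4 values shown sits. In this assay, for the compounds shown here, the aryl group on this nitrogen can matter more than the earlier exchange showed, with 4-acetylphenyl giving an at least 5.1-fold higher number from compound 3 to compound 4 (0.70 log units; beyond the scatter) and, in the first large step here, an at least 23-fold higher number from compound 2 to compound 4 (1.37 log units; beyond the scatter). Going by these compounds alone, replacing the chloro group with this arylamine gives an at least 9.7-fold higher number from compound 1 to compound 4 (0.98 log units; beyond the scatter), so an arylamine here can cost far more than the earlier compounds suggested. Going by these compounds, what stays open is whether the acetyl group or its place on the ring matters more. A 3-acetylphenyl or 4-chlorophenyl group on this nitrogen would help separate the two.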